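The compounds below may be only part of what the source reports. "The series", "measured", "known", "first", "only" and "open" are said of these compounds alone.

In a physicochemical assay for solubility, at pH 7.4 (a lower number here means a less soluble compound, a higher number a more soluble compound), compound 1 `NS(=O)(=O)c1ccc(S(=O)(=O)CCCO)cc1` gives 7200 ug/mL and compound 2 `NS(=O)(=O)c1ccc(S(=O)(=O)CCO)c(F)c1` gives 3300 ug/mL as its reading. Compound 3 `NS(=O)(=O)c1ccc(S(=O)(=O)CCCO)c(C(=O)O)c1` gives 53000 ug/mL as the highest of these three numbers, and it stands clear of both others beyond the scatter. Compound 4 `Nc1cc(S(N)(=O)=O)ccc1S(=O)(=O)CCCO` is still unmeasured and differs from compound 3 by a single change, amino in place of carboxy on an aromatic carbon. Carboxy in place of hydrogen on an aromatic carbon is the only measured step that bears on this change. That step was modest yet beyond the scatter (a 7.4-fold higher number from compound 1 to compound 3 (0.87 log units; beyond the scatter)) and is expected to be roughly reversed when the carboxy leaves. Going by the values given here, no measured step shows amino at this place, so its own contribution stays open. A step of similar size towards a lower number is therefore expected in this assay for compound 4. The estimated step is an 8.8-fold lower number from compound 3 to compound 4 (0.95 log units; beyond the scatter) in size and direction. For compound 4 the estimated value is 6000 ug/mL with an expected range of 1500 ug/mL to 20000 ug/mL for the measurement.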

Compound 4, solubility: 8400 ug/mL
The estimate for compound 4 lay 1.4-fold (0.15 log units) below the measured number; low and high end bracket the measured number.
By their numbers in this assay, from the lowest: compound 2; then compounds 1 and 4 (each within the scatter of the next); then compound 3.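

In this assay, going by these compounds alone, the swap of carboxy for amino on this aromatic carbon brings a clear drop (a 6.3-fold lower number from compound 3 to compound 4 (0.80 log units; beyond the scatter)), which is the first direct look at what happens when the carboxy is replaced by another small group rather than by hydrogen. Amino and hydrogen at this place cannot be told apart (a 1.2-fold higher number from compound 1 to compound 4 (0.07 log units; within the scatter)), so among the three groups seen here, only carboxy sets its compound apart, and adding amino to the core of compound 1 leaves the reading where it was.

Going by these compounds, how a methyl ester of the carboxylic acid, a carboxamide or a methyl group on this same aromatic carbon would read remains open. Nothing measured here explains why these groups give the readings they do.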